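The source may report more compounds than this note shows. Statements on the series, on what has been measured and on what is new or still open speak of the compounds shown alone.

In an ADME assay on a cell-free system (plasma, Rattus norvegicus, strain Sprague-Dawley) for protein binding, read by LC-MS, with a stated time of 5 h, tested at 5 uM, compound 1 `COc1cc(OCc2ccnc(N)c2Cl)cc2sc(N[C@@H]3CCCC[C@H]3O)nc12` reads > 99%, which is a limit of the assay and not a number. For the measured compounds named here, compound 2 `COc1cc(OCc2ccnc(N)n2)cc2sc(N[C@@H]3CCCC[C@H]3O)nc12` gives 90.4%, so it is the only compound so far with an actual number. Going by the values given here, the single measured step, an at least 9.6-fold higher unbound fraction from compound 1 to compound 2 (0.98 log units; beyond the scatter), comes with 2-aminopyrimidin-4-yl in place of 2-amino-3-chloropyridin-4-yl, a change of group that lies beyond the scatter.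

Compound 3 `COc1cc(OCc2ccnc(N)n2)cc2sc(N[C@H]3CCCC[C@@H]3O)nc12` is a different case: the two compounds have the same atoms and bonds and differ only in configuration as drawn: 2 of 2 stereo elements differ (all stereocentres are inverted: mirror images); a stereocentre at a saturated ring carbon is drawn R in compound 2 and S in compound 3; a stereocentre at a saturated ring carbon is drawn R in compound 2 and S in compound 3. Nothing leaves and nothing enters, and the two compounds are mirror images, with all stereocentres inverted. The step an at least 9.6-fold higher unbound fraction from compound 1 to compound 2 (0.98 log units; beyond the scatter) therefore does not bear directly on this change, as it swaps a group and leaves the configuration as drawn untouched. Among the compounds with values here, no measured pair here tests configuration, so no direction can be argued from the data, and the expectation starts from compound 2 at 90.4%. The expected change is small, and the estimate amounts to a 1.0-fold higher unbound fraction from compound 2 to compound 3 (0.02 log units; within the scatter), none beyond the scatter. For compound 3 the estimated value is 90%, with an expected range from 81% to 96%.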

Compound 3, plasma protein binding: 92.2%
The estimate for compound 3 lay 1.3-fold (0.11 log units) (unbound fraction) above the measured number, within the range that was stated.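

The mirror-image pair gives the first measured test of configuration in this assay, and it shows a 1.2-fold lower unbound fraction from compound 2 to compound 3 (0.09 log units; within the scatter). Inverting both stereocentres at the saturated ring carbons therefore does not separate these two compounds in this assay, whereas the earlier change of group gave an at least 9.6-fold higher unbound fraction from compound 1 to compound 2 (0.98 log units; beyond the scatter). Both members of the new pair carry actual numbers, so the size of this step can be read directly, and it concerns configuration alone: the fact that compounds 2 and 3 differ only in the configuration as drawn

The compounds shown leave open whether inverting only one of the two stereocentres would give a value within the scatter of compound 2 as well, and whether configuration would matter as little with 2-amino-3-chloropyridin-4-yl in place of 2-aminopyrimidin-4-yl. They also leave open how plasma protein binding would respond if a carboxylic acid or an amine stood in place of the hydroxyl group on the saturated ring, a change that none of the compounds shown makes.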